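A few compounds are considered here, and "the series" means these few. Any claim that something is new, unique, unknown or untested is made for them only; others in the source may bear on it.

Three compounds share one core and differ only in the group attached to the phenyl ring. Compound 1, `COc1cccc(C(O)CCn2nc3c(Br)c(Br)c(Br)c(Br)c3n2)c1`, carries a methoxy group; in a functional assay on MCF7 cells (Homo sapiens) for antiproliferative activity, read by MTT assay, with a stated time of 48 h, tested at 25 uM (on this read-out lower numbers stand for a stronger effect and higher numbers for a weaker effect at the one concentration tested), compound 1 gives 96%. Compound 2, `OC(CCn1nc2c(Br)c(Br)c(Br)c(Br)c2n1)c1cccc(Cl)c1`, carries a chloro group, and in this assay compound 2 gives 101%. Compound 3, `OC(CCn1nc2c(Br)c(Br)c(Br)c(Br)c2n1)c1ccccc1`, carries a hydrogen in that place, and in this assay compound 3 gives 105%. On the numbers shown compound 3 stands highest of the three, yet the steps of a number 4 percentage points higher from compound 2 to compound 3 (within the scatter) and a number 9 percentage points higher from compound 1 to compound 3 (within the scatter) both lie within the scatter, as does the step of a number 5 percentage points higher from compound 1 to compound 2 (within the scatter), so the three behave alike in this assay.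

Compound 4, `OC(CCn1nc2c(Br)c(Br)c(Br)c(Br)c2n1)c1ccc(Br)cc1`, has not yet been measured. It differs from compound 3 in one place: bromo in place of hydrogen on an aromatic carbon. The three measured steps all exchange the group on the same ring, among them a halogen against a hydrogen, and none of them moved the read-out beyond the scatter. A step of a number 2 percentage points lower from compound 3 to compound 4 (within the scatter) is therefore expected, that is, no change beyond the scatter. For compound 4 a value of 103% is estimated, with a range from 90% to 115%.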

Compound 4, a percentage reported as activity, at one concentration (the size of the read-out at that concentration, not a potency): 105%
For compound 4 the middle estimate is 2 percentage points below the measured one, and the stated range covers the measured number.
By their numbers in this assay, from the lowest: compounds 1, 2, 3 and 4 (each within the scatter of the next).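

Compound 4 is the only one of the four whose ring carries a group para to a large group, since the other substituted compounds hold theirs as 3-chlorophenyl and 3-methoxyphenyl, and exchanging phenyl for 4-bromophenyl gives no change at the digits printed from compound 3 to compound 4 (within the scatter) in this assay at this newly occupied place. Replacing 3-chlorophenyl by 4-bromophenyl gives a number 4 percentage points higher from compound 2 to compound 4 (within the scatter) and replacing 3-methoxyphenyl by 4-bromophenyl gives a number 9 percentage points higher from compound 1 to compound 4 (within the scatter) even though each of these two steps changes both the group and its place on the ring. Among these four compounds, then, neither the kind of group nor its place on the ring separates one compound from another at the single concentration tested.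

No measured evidence is available to explain why the read-out stays put at this place. Still open, as far as these compounds go, is whether an amine, a carboxylic acid or a longer chain in place of the bromo would move the read-out beyond the scatter, and whether any such group would do so while the shared core stays the same.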